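The compounds below may be only part of what the source reports. "The series", "measured", "known", "first", "only" and "open" are said of these compounds alone.

Measured so far:
- compound 1 `FC(F)(F)c1ccccc1Cn1nnc2c(NC3CC3)nc(-c3ccccc3)nc21` — in an assay on Cerebral cortex for displacement of a labelled ligand from adenosine receptor A1 (Bos taurus) (a higher number here means a weaker inhibitor, a lower number a stronger inhibitor), compound 1 gives 7.8 nM
- compound 2 `Clc1ccccc1Cn1nnc2c(NC3CCCC3)nc(-c3ccccc3)nc21` — in this assay compound 2 gives 9 nM

Compound 2 carries the higher of the two numbers, but its gap to compound 1 is within the scatter, so the two values show no separation. Within the data shown here, compound 1 and compound 2 differ in two places, and no single step between them is available.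

Compound 3 `FC(F)(F)c1ccccc1Cn1nnc2c(NC3CCCC3)nc(-c3ccccc3)nc21` is not yet measured. The change from compound 2 is trifluoromethyl in place of chloro on an aromatic carbon. Among the measured compounds shown here, no measured step for this change exists. Since compound 1, which carries the trifluoromethyl group, gives 7.8 nM in this assay, and compound 2 gives 9 nM, no step beyond the scatter is expected. The step expected from compound 2 to compound 3 in this assay is a 1.3-fold lower number from compound 2 to compound 3 (0.11 log units; within the scatter). For compound 3 the estimate in this assay is 7 nM, with a range from 2.5 nM to 20 nM.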

Compound 3, inhibition constant: 0.6 nM
For compound 3 the middle estimate is 12-fold (1.07 log units) above the measured one; the measured number lies below the stated range.
By their numbers in this assay, from the lowest: compound 3; then compounds 1 and 2 (each within the scatter of the next).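

In this assay, with cyclopentyl kept on the nitrogen, trifluoromethyl in place of chloro on the aromatic carbon gives a 15-fold lower number from compound 2 to compound 3 (1.18 log units; beyond the scatter) and is a large step at this place, ortho to a large group. With trifluoromethyl kept, cyclopentyl in place of cyclopropyl gives a 13-fold lower number from compound 1 to compound 3 (1.11 log units; beyond the scatter) so the substituent on the nitrogen also moves the number by a large step. The closeness of compound 1 and compound 2, which differ in both places, therefore hid two sensitive places, and among the compounds shown only compound 3 combines trifluoromethyl with cyclopentyl.

Open, from the compounds shown here alone, is whether the trifluoromethyl step holds with cyclopropyl on the nitrogen, and how a bromo or methoxy group at the aromatic carbon, or cyclohexyl on the nitrogen, would compare. Nothing available accounts for either step.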